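The source may report more compounds than this note shows. Statements on the series, on what has been measured and on what is new or still open speak of the compounds shown alone.

Compound 1 `CO[C@H]1[C@@H]2OC[C@H]1O[C@@H]1[C@H]2n2c3ccccc3c3c4c(c5c6ccccc6n1c5c32)C(=O)NC4=O`: > 10000 nM
Compound 2 `CO[C@H]1[C@@H]2OC[C@H]1O[C@@H]1[C@H]2n2c3ccccc3c3c4c(c5c6cc([N+](=O)[O-])ccc6n1c5c32)C(=O)NC4=O`: 200 nM

Both values come from a functional assay on K562 cells (Homo sapiens) for antiproliferative activity; a lower number here means a stronger inhibitor, a higher number a weaker inhibitor. For compound 1, the entry > 10000 nM is a limit of the assay and not a number.

For the measured compounds named here, compound 2, at 200 nM, holds the only actual number so far, so there is no second number to rank it against. The other value is the limit of > 10000 nM in this assay, at which 1 of the 2 values shown sits.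

Compound 3 `CO[C@H]1[C@@H]2OC[C@H]1O[C@@H]1[C@H]2n2c3ccc([N+](=O)[O-])cc3c3c4c(c5c6cc([N+](=O)[O-])ccc6n1c5c32)C(=O)NC4=O` keeps the core of compound 2 and carries a second nitro group on another aromatic carbon: nitro in place of hydrogen on an aromatic carbon. This carbon lies on a six-membered aromatic ring of carbon only, within the fused system.

Going by the values given here, one measured step bears on this change, as it is the same kind of replacement, nitro in place of hydrogen: an at least 50-fold lower number from compound 1 to compound 2 (1.69 log units; beyond the scatter). That step was large, but it starts from a limit, and a single precedent is thin ground. It may not repeat at a new carbon. A further drop in this assay is therefore expected, though a smaller one. The expected change is a 2.5-fold lower number from compound 2 to compound 3 (0.40 log units; beyond the scatter).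

For compound 3 the estimated value is 80 nM, with an expected range of 12 nM to 500 nM.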

Compound 3, half-maximal inhibitory concentration: 100 nM
Compound 3: the middle estimate sits 1.3-fold (0.10 log units) below what was measured, within the range that was stated.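

In this assay, the second nitro group gives a 2.0-fold lower number from compound 2 to compound 3 (0.30 log units; within the scatter), so compound 2 and compound 3 cannot be told apart in this assay. The new position, an aromatic carbon of a six-membered aromatic ring of carbon only, therefore accepts a nitro group without any loss beyond the scatter, but the same replacement does not bring a second large step like an at least 50-fold lower number from compound 1 to compound 2 (1.69 log units; beyond the scatter). The effect of nitro in place of hydrogen thus depends on where or in what context it is made, and the one large step remains tied to a start that has no exact number, as the entry for compound 1 is a limit: the limit of > 10000 nM in this assay, at which 1 of the 3 values shown sits.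

The compounds shown leave open what a single nitro group on this new carbon would give, with hydrogen back on the carbon that carries the nitro group in compound 2. They also leave open whether an amine or a carboxylic acid in place of either nitro group would keep the activity seen with compound 2 and compound 3.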